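Replacing a Dimethylamino Chain with 4-(Pyridin-2-yl)phenyl

This account rests on a few compounds, and the source may have more. Where it says the series, first, only, none or still open, it means among the compounds named here.

In a functional assay on HCT-116 cells (Homo sapiens) for cytotoxicity, read by fluorescence, with a stated time of 72 h (on this read-out lower numbers stand for stronger inhibition and higher numbers for weaker inhibition), compound 1 `CC(C)c1n[nH]c2c(NCc3ccc(-c4ccccn4)cc3)nc(NCCN)nc12` gives 227 nM, and compound 2 `CC(C)c1n[nH]c2c(NCc3ccc(-c4ccccn4)cc3)nc(NCCN(C)C)nc12` gives 390 nM. Within the data shown here, these two numbers lie within the scatter of each other, so compound 2 cannot be told apart from the only other measured compound. Compound 3 `CC(C)c1n[nH]c2c(NCc3ccc(-c4ccccn4)cc3)nc(NCc3ccc(-c4ccccn4)cc3)nc12` differs from compound 2 by one change: 4-(pyridin-2-yl)phenyl in place of (dimethylamino)methyl on a saturated chain carbon bound to a nitrogen on an aromatic ring. Among the measured compounds shown here, the sole measured step, a 1.7-fold higher number from compound 1 to compound 2 (0.24 log units; within the scatter), exchanges amino for dimethylamino and stays within the scatter. For the measured compounds named here, it bears only weakly on the new change, since both measured compounds keep the chain that compound 3 lacks, and no measured compound carries a second 4-(pyridin-2-yl)phenyl. The expected step is a 2.3-fold higher number from compound 2 to compound 3 (0.36 log units; beyond the scatter), a moderate move towards weaker inhibition, and it is uncertain. For compound 3 the estimated value is 900 nM, within an expected range of 200 nM to 4000 nM.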

Compound 3, half-maximal inhibitory concentration: 7330 nM
The estimate for compound 3 lay 8.1-fold (0.91 log units) below the measured number; the whole stated range lies below it.
By their numbers in this assay, from the lowest: compounds 1 and 2 (each within the scatter of the next); then compound 3.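

In this assay the place on a saturated chain carbon bound to a nitrogen on an aromatic ring proves sensitive to what it carries: 4-(pyridin-2-yl)phenyl in place of (dimethylamino)methyl gives a 19-fold higher number from compound 2 to compound 3 (1.27 log units; beyond the scatter) and in place of aminomethyl gives a 32-fold higher number from compound 1 to compound 3 (1.51 log units; beyond the scatter) as well. Compounds 1 and 2 could not show this, since the exchange between them, amino against dimethylamino, stays within the scatter and keeps the chain. Nothing available here accounts for the rise.

The compounds shown leave open whether the rise follows from losing the amine of the chain or from the entry of 4-(pyridin-2-yl)phenyl, as both happen in one change. On these data alone, a longer chain ending in an amine at this place also remains untested among them.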